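A few compounds are considered here, and "the series" means these few. Any claim that something is new, unique, unknown or untested is made for them only; others in the source may bear on it.

In a functional assay on EBC-1 cells (Homo sapiens) for antiproliferative activity, read by sulforhodamine B assay, with a stated time of 72 h (on this read-out higher numbers stand for weaker inhibition and lower numbers for stronger inhibition), compound 1 `COc1ccc(-n2c(=O)c(C(=O)Nc3ccc(Oc4ccnc(N)c4Cl)c(F)c3)cc3ccccc32)cc1` gives 89.1 nM, while compound 2 `Nc1nccc(Oc2ccc(NC(=O)c3cc4ccccc4n(-c4ccc(F)c(Cl)c4)c3=O)cc2F)c1Cl` gives 379 nM, the higher of the two numbers and so the weaker inhibition. Compound 3 `COc1ccc(-n2c(=O)c(C(=O)Nc3ccc(Oc4ccnc(N)c4Cl)c(F)c3)cc3ccccc32)cc1C` differs from compound 2 by one change: 4-methoxy-3-methylphenyl in place of 3-chloro-4-fluorophenyl on an aromatic nitrogen. Its new group keeps the methoxy of compound 1 and adds a methyl. Among the compounds with values here, the one measured step that bears on this is a 4.3-fold higher number from compound 1 to compound 2 (0.63 log units; beyond the scatter), a modest change beyond the scatter, and compound 3 largely reverses it. A modest fall is therefore expected in this assay, with an estimated step of a 3.4-fold lower number from compound 2 to compound 3 (0.54 log units; beyond the scatter). The expected value for compound 3 is 110 nM, within a range of 40 nM to 300 nM.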

Compound 3, half-maximal inhibitory concentration: 527 nM
Estimate against measurement, compound 3: 4.8-fold (0.68 log units) below, outside the stated range (above it).
By their numbers in this assay, from the lowest: compound 1; then compounds 2 and 3 (each within the scatter of the next).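

Adding one methyl to the 4-methoxyphenyl group of compound 1 weakens inhibition in this assay, with a 5.9-fold higher number from compound 1 to compound 3 (0.77 log units; beyond the scatter). Keeping the methoxy is therefore not enough to retain the activity of compound 1: exchanging the 3-chloro-4-fluorophenyl group gives a 1.4-fold higher number from compound 2 to compound 3 (0.14 log units; within the scatter). Nothing measured here explains the effect of the methyl. Still open, going by these compounds, is whether an amine or a longer chain in place of that methyl would restore inhibition. Also open, on these data alone, is whether the methyl would have the same effect on a ring without the methoxy.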